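The source may report more compounds than this note shows. Statements on the series, on what has been measured and on what is new or still open speak of the compounds shown alone.

Three compounds of the series have been run in a functional assay on HepG2 cells (Homo sapiens) for cytotoxicity, read by MTT assay, with a stated time of 48 h; on this read-out lower numbers stand for stronger inhibition and higher numbers for weaker inhibition. Compound 1 `CCOC(=O)CSc1nnc(C)n1N1C(=O)c2ccccc2C1=O` gives only a limit of the assay, > 200000 nM in this assay. Compound 2 `Cc1ccc(C(=O)CSc2nnc(C)n2N2C(=O)c3ccccc3C2=O)cc1` likewise stands at a limit, with > 200000 nM in this assay. Compound 3 `Cc1nnc(SCc2ccccc2Cl)n1N1C(=O)c2ccccc2C1=O` also returns a limit, > 200000 nM in this assay. Because all three sit at the limit of > 200000 nM in this assay, at which 3 of the 3 values shown sit, none of the steps among them can be read: the step that the two limits leave unreadable from compound 1 to compound 2, the step that the two limits leave unreadable from compound 1 to compound 3 and the step that the two limits leave unreadable from compound 2 to compound 3 are each unreadable in size and direction. Compound 2 therefore stands at the limit, with no number behind it and no measured neighbour that resolves its position.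

Compound 4 `CCc1nnc(SCC(=O)c2ccc(C)cc2)n1N1C(=O)c2ccccc2C1=O` differs from compound 2 by methyl in place of hydrogen on a saturated chain carbon bound to an aromatic carbon. Going by the values given here, none of the three measured steps touches this part of the shared core, and none of them is readable, so the series supplies no size and no direction for the step from compound 2 to compound 4. The step of a number no higher from compound 2 to compound 4 (the limit leaves the size open) is expected to stay within the scatter, and compound 4 is expected to come back as a limit as well. Compound 4 is estimated at 200000 nM, with a range from 100000 nM to 400000 nM.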

Compound 4, half-maximal inhibitory concentration: > 200000 nM
Compound 4: a limit, no number (the forecaster's own chance of this, stated with the estimate: 85%); the middle value lies on the limit itself.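

No new step can be read: compound 2 and compound 4 both stand at a limit, so the step between them has neither size nor direction, because the series offers no number to compare: the limit of > 200000 nM in this assay, at which 4 of the 4 values shown sit.

The compounds shown leave open whether any change on the shared core of compound 1, compound 2, compound 3 and compound 4 alters the read-out in this assay.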